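Hydroxy in place of hydrogen on the cyclodepsipeptide side chain

This account rests on a few compounds, and the source may have more. Where it says the series, first, only, none or still open, it means among the compounds named here.

The series is followed in a functional assay on HepG2 cells (Homo sapiens) for antiproliferative activity; a higher number here means a weaker inhibitor, a lower number a stronger inhibitor. For the measured compounds named here, compound 2, `CC[C@H](C)[C@H]1C(=O)N[C@H](Cc2cc(Cl)c(O)c(Cl)c2)C(=O)N[C@@H](C(C)C)C(=O)O[C@H](c2ccccc2)[C@H](C)/C=C/C=C(\C)[C@H](OC)C/C=C(\C)C(=O)N1C`, is the only member with a numerical value: compound 2 gives 104 nM. Compound 1, `CC[C@H](C)[C@H]1C(=O)N[C@H](Cc2cc(Cl)c(O)c(Cl)c2)C(=O)N[C@@H](C(C)(C)O)C(=O)O[C@H](c2ccccc2)[C@H](C)/C=C/C=C(\C)[C@H](OC)C[C@H]2O[C@]2(C)C(=O)N1C`, reaches only a limit of the assay, and compound 1 gives > 200 nM. Going by the values given here, compound 1 differs from compound 2 in two places, so no single step can be read between them; the two values show only that compound 1 sits at the limit while compound 2 has a measured number, as noted by the limit of > 200 nM in this assay, at which 1 of the 2 values shown sits.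

Compound 3, `CC[C@H](C)[C@H]1C(=O)N[C@H](Cc2cc(Cl)c(O)c(Cl)c2)C(=O)N[C@@H](C(C)(C)O)C(=O)O[C@H](c2ccccc2)[C@H](C)/C=C/C=C(\C)[C@H](OC)C/C=C(\C)C(=O)N1C`, is not yet measured. It differs from compound 2 in one place: hydroxy in place of hydrogen on a saturated chain carbon bound to two saturated chain carbons and a saturated ring carbon. The rest of the shared core, including the alkene in place of the epoxide, is kept as in compound 2.

Among the compounds with values here, no measured step for this change is available. The expectation is a weakening step, set against the fact that compound 1 also carries the hydroxy group and gives only a limit; the expected step is a 2.5-fold higher number from compound 2 to compound 3 (0.40 log units; beyond the scatter). Compound 3 is estimated at 260 nM, within 90 nM to 800 nM, with a real chance that only a limit is reported.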

Compound 3, half-maximal inhibitory concentration: 2.75 nM
For compound 3 the middle estimate is 95-fold (1.98 log units) above the measured one; the whole stated range lies above it.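

In this assay, for the compounds shown here, the change from isopropyl to 1-hydroxy-1-methylethyl on the core with the alkene gives a 38-fold lower number from compound 2 to compound 3 (1.58 log units; beyond the scatter), the first single-place reading at this carbon and a sign that the series responds strongly to a change here. The 1-hydroxy-1-methylethyl group therefore does not by itself go with weak antiproliferative activity, as compound 1 alone might have suggested, and on this core it goes with the lowest number shown. Compound 1 carries the same group with the epoxide in place of the alkene and stays at a limit of the assay, so the step from compound 3 to compound 1 cannot be read as a number: the limit of > 200 nM in this assay, at which 1 of the 3 values shown sits.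

The compounds shown leave open whether the gain belongs to the hydroxy group itself or would also appear with a methoxy group, an amine or a fluorine on the same saturated chain carbon. Also open, going by these compounds, are the cause of the step and whether the same change from isopropyl carries over to the core with the epoxide.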